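From compound 2 to compound 4: one halogenated ring exchanged

The source may report more compounds than this note shows. Statements on the series, on what has been measured and on what is new or still open speak of the compounds shown alone.

Values in a functional assay on MDA-MB-231 cells (Homo sapiens) for cytotoxicity, read by MTT assay, with a stated time of 24 h; on this read-out lower numbers stand for stronger inhibition and higher numbers for weaker inhibition:
Compound 1 `COc1ccc(/C=C2\CN(C(=S)SCc3cn(Cc4ccccc4F)nn3)C/C(=C\c3ccc(OC)cc3)C2=O)cc1`: > 100000 nM, a limit
Compound 2 `O=C1/C(=C/c2ccccc2F)CN(Cc2cn(Cc3ccccc3F)nn2)C/C1=C\c1ccccc1F`: 16000 nM
Compound 3 `COc1ccc(/C=C2\CN(C(=S)SCc3cn(Cc4ccc(F)cc4)nn3)C/C(=C\c3ccc(OC)cc3)C2=O)cc1`: > 100000 nM, a limit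

Among the measured compounds shown here, compound 2 carries the only true number in this small set, and the other two compounds sit at the limit of > 100000 nM in this assay, at which 2 of the 3 values shown sit. Compound 4 `O=C1/C(=C/c2ccccc2F)CN(Cc2cn(Cc3cccc(Cl)c3)nn2)C/C1=C\c1ccccc1F` departs from compound 2 by one exchange: 3-chlorophenyl in place of 2-fluorophenyl on a saturated chain carbon bound to an aromatic nitrogen. The same difference reads as 2-fluorobenzyl to 3-chlorobenzyl. For the measured compounds named here, the only measured step at this place is a step that the two limits leave unreadable from compound 1 to compound 3, and it offers no size to carry over. The expectation therefore rests on compound 2 at 16000 nM. The expected change, no change at the digits printed from compound 2 to compound 4 (within the scatter), is none beyond the scatter, in either direction. In this assay the estimated value for compound 4 is 16000 nM, with an expected range from 6000 nM to 40000 nM.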

Compound 4, half-maximal inhibitory concentration: 12000 nM
Beside the measured number, compound 4's estimate is 1.3-fold (0.12 log units) above it; the measured number falls inside the stated range.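

In this assay, this position now gives its first readable step, a 1.3-fold lower number from compound 2 to compound 4 (0.12 log units; within the scatter). On the core of compound 2, 2-fluorobenzyl and 3-chlorobenzyl therefore read alike. The earlier step at this place, between compounds 1 and 3, cannot be read, as both values are limits: the limit of > 100000 nM in this assay, at which 2 of the 4 values shown sit.

What the compounds shown leave open is how this position responds to a group other than a halogenated benzyl, such as a benzyl carrying an amine or a carboxylic acid, or a longer chain ending in a phenyl ring.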